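This account rests on a few compounds, and the source may have more. Where it says the series, first, only, none or still open, it means among the compounds named here.

Measured so far:
Compound 1, `COc1cc(C(C)=O)ccc1OCCCN1CCC(CC(c2ccc(F)cc2)c2ccc(F)cc2)CC1`: 3.16 nM
Compound 2, `COc1cc(OCCCN2CCC(C(c3ccc(F)cc3)c3ccc(F)cc3)CC2)ccc1C(C)=O`: 3.16 nM

Both compounds were tested in a functional assay (aorta) with Oryctolagus cuniculus as the target; on this read-out higher numbers stand for weaker binding and lower numbers for tighter binding. In this assay compound 1 gives 3.16 nM, and compound 2 gives 3.16 nM. Compound 2 therefore stands level with compound 1 at the digits shown; the two values fall within the usual scatter of this kind of measurement, so no order between them can be claimed, and the small structural difference between the two leaves no visible mark on the read-out.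

Compound 3, `O=S(=O)(CCCN1CCC(C(c2ccc(F)cc2)c2ccc(F)cc2)CC1)c1ccccc1`, has not yet been measured in this assay. It differs from compound 2 in one place: phenylsulfonyl in place of 4-acetyl-3-methoxyphenoxy on a saturated chain carbon, three bonds along the chain from an amine nitrogen in a ring. Among the compounds with values here, no measured step between any pair of compounds is available here, so the size of this change cannot be read from a precedent and has to be estimated. The group that leaves is larger than the group that enters and carries one more hydrogen-bond acceptor, and the expectation is a moderate step toward weaker binding, somewhat beyond the scatter but not large. Compound 3 is expected to give about 10 nM, with a likely range from 2 nM to 50 nM. This corresponds to an expected step of a 3.2-fold higher number from compound 2 to compound 3 (0.50 log units; beyond the scatter) in this assay.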

Compound 3, dissociation constant: 20 nM
Estimate against measurement, compound 3: 2.0-fold (0.30 log units) below; low and high end bracket the measured number.
By their numbers in this assay, from the lowest: compounds 1 and 2 (each within the scatter of the next); then compound 3.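

Swapping 4-acetyl-3-methoxyphenoxy for phenylsulfonyl, on a saturated chain carbon three bonds along the chain from an amine nitrogen in a ring, gives the first single-place step on record in this assay: a 6.3-fold higher number from compound 2 to compound 3 (0.80 log units; beyond the scatter). This shows that the read-out does respond to the group at this position, since the step lies beyond the usual scatter, although its size is only modest. Both groups carry one six-membered aromatic ring of carbon only, so this step shows that keeping such a ring at this position does not by itself hold the number level, while nothing available explains why the number moves by this amount.

The swap alters the link to the ring and removes the acetyl and methoxy groups in one step, so the compounds shown cannot divide the change among these parts. A plain phenoxy group or a benzoyl group at this place would help to separate them, and a longer chain would test whether the distance from the amine nitrogen also counts.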